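The compounds below may be only part of what the source reports. "The series", "measured", "known", "first", "only" and "open" are said of these compounds alone.

Compound 1, `Cc1ccccc1N/N=C1\CCC(C)n2c1ncc(C(=O)O)c2=O`: in a functional assay on the whole organism for inhibition, with Rattus norvegicus as the target (a lower number here means that less compound is needed, a higher number that more compound is needed for the effect), compound 1 gives > 100 umol/kg, a limit of the assay and not a number.
Compound 2, `Cc1ccc(N/N=C2\CCC(C)n3c2ncc(C(=O)O)c3=O)cc1`: in this assay compound 2 gives > 1000 umol/kg, again a limit rather than a number.

Compound 2 thus stands at a limit in this assay, namely (the limit of > 1000 umol/kg in this assay, at which 1 of the 2 values shown sits). Compound 1 sits at a different limit, (the limit of > 100 umol/kg in this assay, at which 1 of the 2 values shown sits). Among the measured compounds shown here, the only measured step, a step that the two limits leave unreadable from compound 1 to compound 2, joins two limits, so its size cannot be read, and no measured step gives a usable size for the change ahead.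

Compound 3, `CC1CC/C(=N\Nc2ccc(CC(=O)O)cc2)c2ncc(C(=O)O)c(=O)n21`, has not yet been measured. It differs from compound 2 by carboxy in place of hydrogen on a saturated chain carbon bound to an aromatic carbon. With no readable step to lean on, the expectation in this assay is for no step beyond the scatter, a number no higher from compound 2 to compound 3 (the limit leaves the size open), and most likely another limit. For compound 3 the estimated value is 1000 umol/kg, with a range from 300 umol/kg to 3000 umol/kg.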

Compound 3, dose for 50% inhibition: > 100 umol/kg
Compound 3 ended at the assay's limit; the forecaster's own chance of this, stated with the estimate: 80%; the middle value lies beyond the limit too.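

The step between compound 2 and compound 3 joins two limits of the assay, not two numbers, and its size cannot be read. The compounds shown leave open what dose compound 1, compound 2 or compound 3 actually needs in this assay, and whether carboxy in place of hydrogen changes that dose at all.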